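Swapping one hydroxyalkyl arm for another on the shared core

This account rests on a few compounds, and the source may have more. Where it says the series, first, only, none or still open, it means among the compounds named here.

Compound 1 `OCc1cn(CCNc2nonc2/C(=N/O)Nc2ccc(F)c(Br)c2)nn1` gives 794 nM in an assay on isolated protein for inhibition of Indoleamine 2,3-dioxygenase 2 (Homo sapiens); a higher number here means a weaker inhibitor, a lower number a stronger inhibitor.
Compound 2 `OCCCCc1cn(CCNc2nonc2/C(=N/O)Nc2ccc(F)c(Br)c2)nn1` gives 1080 nM in this assay.
Compound 3 `CCC(O)c1cn(CCNc2nonc2/C(=N/O)Nc2ccc(F)c(Br)c2)nn1` gives 947 nM in this assay.

Among these three numbers, compound 3 holds the second highest, yet every one of them sits within the scatter of the others, so the three read as one level. The step to compound 4 `CC(OCCO)c1cn(CCNc2nonc2/C(=N/O)Nc2ccc(F)c(Br)c2)nn1` is 1-(2-hydroxyethoxy)ethyl in place of 1-hydroxypropyl on an aromatic carbon.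

Among the compounds with values here, three measured steps bear on it, since each one also reshapes the side arm on the same aromatic carbon. The step of a 1.2-fold higher number from compound 1 to compound 3 (0.08 log units; within the scatter) lengthens the arm, the step of a 1.4-fold higher number from compound 1 to compound 2 (0.13 log units; within the scatter) moves the hydroxyl further out, and the step of a 1.1-fold lower number from compound 2 to compound 3 (0.06 log units; within the scatter) changes both length and position of the hydroxyl. None of them reached beyond the scatter. Within the data shown here, the arm in compound 4 is again a chain carrying a hydroxyl, with an added oxygen in the chain, and nothing measured so far suggests that changes here move this assay much. The expected step is therefore a 1.1-fold higher number from compound 3 to compound 4 (0.02 log units; within the scatter), within the scatter. Compound 4 is estimated at 1000 nM, with a range from 450 nM to 2200 nM.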

Compound 4, half-maximal inhibitory concentration: 930 nM
Compound 4: middle estimate off by 1.1-fold (0.03 log units), on the high side; measured number inside the range.
By their numbers in this assay, from the lowest: compounds 1, 4, 3 and 2 (each within the scatter of the next).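

The new arm, 1-(2-hydroxyethoxy)ethyl, is larger than 1-hydroxypropyl, with 6 heavy atoms against 4 and 2 hydrogen-bond acceptors against 1, and it places an oxygen inside the chain, yet this assay shows only a step within the scatter (a 1.0-fold lower number from compound 3 to compound 4 (0.01 log units; within the scatter)). The comparisons with the other two arms read the same way (a 1.2-fold lower number from compound 2 to compound 4 (0.06 log units; within the scatter); a 1.2-fold higher number from compound 1 to compound 4 (0.07 log units; within the scatter)), so all four compounds now stand at one level, and this aromatic carbon of the five-membered ring accepts an ether oxygen in the arm as readily as the earlier changes in chain length and hydroxyl position. No independent measurement is available to explain why the number stays so level across these arms.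

Every arm shown still carries a hydroxyl, so it remains open whether an amine, a carboxylic acid or a plain ethyl group on this carbon would stay at the same level. As far as these compounds go, how a much longer chain or a phenyl ring at this place would read in this assay also remains open.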